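Replacing the dimethylpiperazine of compound 3

The source may hold more compounds than are shown below. What is called first, only, known or untested is meant among the compounds shown, and "the series" means these compounds.

Three compounds sharing one core have numbers in a functional assay on V79 cells (Cricetulus griseus) for cytotoxicity, read by colony formation; on this read-out higher numbers stand for weaker inhibition and lower numbers for stronger inhibition. With pyrrolidin-1-yl, compound 1 `O=C(O)c1cn(C2CC2)c2c(F)c(N3CCCC3)c(F)cc2c1=O` gives 120 ug/mL. With 3-(aminomethyl)pyrrolidin-1-yl, compound 2 `NCC1CCN(c2c(F)cc3c(=O)c(C(=O)O)cn(C4CC4)c3c2F)C1` gives 11 ug/mL. With 3,5-dimethylpiperazin-1-yl, compound 3 `CC1CN(c2c(F)cc3c(=O)c(C(=O)O)cn(C4CC4)c3c2F)CC(C)N1` gives 150 ug/mL. Compound 3 therefore sits level with compound 1, the step being a 1.3-fold higher number from compound 1 to compound 3 (0.10 log units; within the scatter), and the two stand together at the high end of the numbers. A much larger gap separates compound 3 from compound 2, namely a 14-fold higher number from compound 2 to compound 3 (1.13 log units; beyond the scatter).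

Compound 4 `NC1CCN(c2c(F)cc3c(=O)c(C(=O)O)cn(C4CC4)c3c2F)CC1` has not yet been measured. Its change is 4-aminopiperidin-1-yl in place of 3,5-dimethylpiperazin-1-yl on an aromatic carbon, ortho to two fluoro groups.

Two large steps bear on it. Aminomethyl in place of hydrogen on a saturated ring carbon gave an 11-fold lower number from compound 1 to compound 2 (1.04 log units; beyond the scatter), and compound 2 is the only measured compound with an amino group carried on a ring carbon, a feature compound 4 shares. The data hold no measured aminopiperidine, so only part of that move is expected to carry over. A clear move to a lower number is expected, the estimated step being a 5.0-fold lower number from compound 3 to compound 4 (0.70 log units; beyond the scatter). For compound 4 the estimated value is 30 ug/mL, with an expected range of 8 ug/mL to 100 ug/mL.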

Compound 4, half-maximal inhibitory concentration: 23 ug/mL
Compound 4: middle estimate off by 1.3-fold (0.12 log units), on the high side, and the stated range covers the measured number.
By their numbers in this assay, from the lowest: compound 2; then compound 4; then compounds 1 and 3 (each within the scatter of the next).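

In this assay, low numbers at this aromatic carbon, ortho to two fluoro groups, do not belong to 3-(aminomethyl)pyrrolidin-1-yl alone: 4-aminopiperidin-1-yl, on a six-membered non-aromatic ring, also lowers the number clearly (a 6.5-fold lower number from compound 3 to compound 4 (0.81 log units; beyond the scatter); a 5.2-fold lower number from compound 1 to compound 4 (0.72 log units; beyond the scatter)). The counts of hydrogen-bond donors and acceptors are the same for 3,5-dimethylpiperazin-1-yl and 4-aminopiperidin-1-yl, so those counts do not separate compound 3 from compound 4 even though their numbers differ. The two groups carrying an amino function on the ring are still not interchangeable, since a modest gap remains between them (a 2.1-fold higher number from compound 2 to compound 4 (0.32 log units; beyond the scatter)). Nothing available gives a reason for any of these steps.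

Compound 2 and compound 4 differ in both ring size and the carbon link to the amine, so the gap between them cannot be assigned to either feature, and 3-aminopyrrolidin-1-yl and 4-(aminomethyl)piperidin-1-yl would pull the two apart. On these data alone, whether the amine itself matters also remains open, and a hydroxyl group in its place on the same ring carbon would address that.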